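Oxazole series: alcohol analogue carrying a carboxypyridine

The source may hold more compounds than are shown below. What is called first, only, known or untested is meant among the compounds shown, and "the series" means these compounds.

Measured so far in an assay for inhibition of Fatty-acid amide hydrolase 1 (Rattus norvegicus); on this read-out higher numbers stand for weaker inhibition and lower numbers for stronger inhibition:
- compound 1, `NC(=O)c1cccc(-c2cnc(C(O)CCc3ccc(-c4ccccc4)cc3)o2)n1`, gives 20000 nM
- compound 2, `NC(=O)c1ccc(-c2cnc(C(=O)CCc3ccc(-c4ccccc4)cc3)o2)nc1`, gives 1.3 nM
- compound 3, `COC(=O)c1cccc(-c2cnc(C(=O)CCc3ccc(OC4CCN(C(=O)OC(C)(C)C)CC4)cc3)o2)n1`, gives 32 nM

Compound 1 stands at the highest number of the three. Compound 3 is nearest to it and compound 2 furthest, and both gaps lie beyond the scatter. For the measured compounds named here, compound 2 differs from compound 1 in more than one place, so its value shows only that the combined changes go with a far lower number; no single step between measured compounds isolates either change.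

Compound 4, `O=C(O)c1ccc(-c2cnc(C(O)CCc3ccc(-c4ccccc4)cc3)o2)nc1`, is to be measured in this assay. It differs from compound 1 by 5-carboxypyridin-2-yl in place of 6-carbamoylpyridin-2-yl on an aromatic carbon, while the alcohol of compound 1 is kept. Going by the values given here, no measured pair tells what this exchange alone does. The step from compound 1 to compound 4 is expected to be small, a 1.3-fold lower number from compound 1 to compound 4 (0.12 log units; within the scatter), with no direction beyond the scatter. Compound 4 is therefore expected near 15000 nM, in a range from 3000 nM to 60000 nM, and a limit rather than a number is a real possibility.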

Compound 4, inhibition constant: 10000 nM
Beside the measured number, compound 4's estimate is 1.5-fold (0.18 log units) above it; measured number inside the range.
By their numbers in this assay, from the lowest: compound 2; then compound 3; then compounds 4 and 1 (each within the scatter of the next).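

Exchanging 6-carbamoylpyridin-2-yl for 5-carboxypyridin-2-yl on the aromatic carbon next to the ring oxygen gives a 2.0-fold lower number from compound 1 to compound 4 (0.30 log units; within the scatter) in this assay. With the alcohol kept, this read-out therefore does not separate the two groups, even though both the group and its attachment on the pyridine ring differ. No available evidence gives a reason for this result.

On these data alone, it remains open whether the same exchange would also leave the number within the scatter with a ketone in place of the alcohol, and what replacing the alcohol with a ketone does on its own. An unsubstituted pyridin-2-yl, or a pyridine ring bearing an amine or a nitrile, would test whether any group at this position moves the number while the alcohol is kept.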